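The source may report more compounds than this note shows. Statements on the series, on what has been measured and on what is new or still open speak of the compounds shown alone.

Compound 2 `CC(C)c1cccc(C(C)C)c1NC(=O)NCC1(c2cccc([N+](=O)[O-])c2)CCCC1` gives the higher of the two numbers measured in an assay on microsomes for inhibition of acyl-CoA:cholesterol acyltransferase (Oryctolagus cuniculus) (a higher number here means a weaker inhibitor, a lower number a stronger inhibitor), at 51 nM; its nearest neighbour is compound 1 `Cc1cccc(C2(CNC(=O)Nc3c(C(C)C)cccc3C(C)C)CCCC2)c1`, which in this assay gives 15 nM. Among the measured compounds shown here, the only step measured between these two, a 3.4-fold higher number from compound 1 to compound 2 (0.53 log units; beyond the scatter), is the one change from which compound 2 itself arose. Compound 3 `CC(C)c1cccc(C(C)C)c1NC(=O)NCC1(c2ccc(N)cc2)CCCC1` differs from compound 2 in the change (4-aminophenyl in place of 3-nitrophenyl on a saturated ring carbon). For the measured compounds named here, this step has no direct counterpart in what has been measured: the nitro group that enters in the step from compound 1 to compound 2 now leaves again, and an amino group enters on the same ring, so the measured step speaks to it only in part. Since the step from compound 1 to compound 2 was modest and compound 3 loses the nitro group, a number for compound 3 that comes back part of the way towards compound 1 is expected, with the step of a 1.7-fold lower number from compound 2 to compound 3 (0.23 log units; within the scatter) thought likely. Compound 3 is therefore estimated at 30 nM in this assay, with a range from 10 nM to 100 nM.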

Compound 3, half-maximal inhibitory concentration: 29 nM
Estimate against measurement, compound 3: 1.0-fold (0.01 log units) above; the measured number falls inside the stated range.
By their numbers in this assay, from the lowest: compounds 1, 3 and 2 (each within the scatter of the next, the first and the last beyond it).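

In this assay, the aromatic ring on the saturated ring carbon of the five-membered ring takes the amino group without a step beyond the scatter: there is a 1.8-fold lower number from compound 2 to compound 3 (0.25 log units; within the scatter), and a 1.9-fold higher number from compound 1 to compound 3 (0.29 log units; within the scatter). Compound 1 and compound 2 stand apart, with a 3.4-fold higher number from compound 1 to compound 2 (0.53 log units; beyond the scatter), but compound 3 cannot be ordered against either of them, so it does not extend that separation in either direction. For these three compounds, then, 4-aminophenyl, with its hydrogen-bond donor, sits at this place with a number not distinguishable from those of 3-methylphenyl and 3-nitrophenyl.

Nothing at hand bears on why the numbers fall as they do. Since 4-aminophenyl differs from 3-nitrophenyl both in the group and in the number within its name, the compounds shown do not separate these two changes, and they leave open whether a larger or charged group on the same six-membered aromatic ring, such as a carboxylic acid or a dimethylamino group, would also stay within the scatter of compound 3.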